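Methyl on the allylamino nitrogen of compound 2

The source may report more compounds than this note shows. Statements on the series, on what has been measured and on what is new or still open speak of the compounds shown alone.

In an ADME assay on Vero cells (Chlorocebus sabaeus) for cytotoxicity, with a stated time of 5 days (a lower number here means a stronger inhibitor, a higher number a weaker inhibitor), compound 1 `C=CCNc1ncnc2c1ncn2[C@H]1C[C@H](N=[N+]=[N-])[C@@H](CO)O1` gives > 100000 nM, which is a limit of the assay and not a number. Compound 2 `C=CCNc1nc(N)nc2c1ncn2[C@H]1C[C@H](N=[N+]=[N-])[C@@H](CO)O1` gives > 100000 nM, again a limit and not a number. Within the data shown here, compound 3 `[N-]=[N+]=N[C@H]1C[C@H](n2cnc3c(N)nc(F)nc32)O[C@@H]1CO` gives 34400 nM, the only true number among the three. Compound 2 therefore has no exact position on the scale, and what can be read so far is the limit of > 100000 nM in this assay, at which 2 of the 3 values shown sit.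

Compound 4 `C=CCN(C)c1nc(N)nc2c1ncn2[C@H]1C[C@H](N=[N+]=[N-])[C@@H](CO)O1` differs from compound 2 in one place, where allylamino becomes allyl(methyl)amino: methyl in place of hydrogen on a nitrogen on an aromatic ring. Among the measured compounds shown here, the one measured step between closely related compounds is a step that the two limits leave unreadable from compound 1 to compound 2. It involves a different change and offers no size to carry over. For the measured compounds named here, no measured step shows what this methyl does in this assay, so no direction can be argued from the data, and no shift beyond the usual scatter is expected. The expected step is a number no higher from compound 2 to compound 4 (the limit leaves the size open), and another limit would be the likeliest report. For compound 4, the estimated value is 100000 nM, with an expected range from 40000 nM to 200000 nM.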

Compound 4, half-maximal inhibitory concentration: 32000 nM
Compound 4: middle estimate off by 3.1-fold (0.49 log units), on the high side; measured number outside the range, below it.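

In this assay, the nitrogen on the aromatic ring that carries the allyl group proves to be a place where a very small change can be read: methyl in place of hydrogen gives an at least 3.1-fold lower number from compound 2 to compound 4 (0.49 log units; beyond the scatter). The step from compound 1 to compound 2 cannot be read, so this is the only step with a measured size among the compounds shown, and it points to a stronger inhibitor of the cells after a single added carbon. The size is only a minimum, and the true step could be larger, because compound 2 stands at a limit of the assay and not at a number: the limit of > 100000 nM in this assay, at which 2 of the 4 values shown sit.

Going by these compounds, it remains open whether any group on this nitrogen would lower the number or whether the result is particular to methyl, and an ethyl group or a longer chain in the same place would begin to answer that. Also open, on these data alone, are why the number moves at all and whether methyl on the same nitrogen of compound 1, which lacks the amino group of compound 2, would move it in the same direction.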